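Removing One Hydroxy Group from a Bromophenol

The compounds below may be only part of what the source reports. "The series", "measured", "known", "first", "only" and "open" are said of these compounds alone.

Compound 1 `Oc1ccc(Cc2cc(O)c(Br)cc2O)cc1`: 13.9 ug/mL 
Compound 2 `COc1ccc(-c2nn(-c3ccccc3)cc2/C=C2\SC(=O)N(Cc3ccccc3)C2=O)cc1`: 127 ug/mL 

Of the compounds shown here, two have been measured so far in a functional assay; a lower number here means a stronger inhibitor, a higher number a weaker inhibitor. Compound 1 gives 13.9 ug/mL and compound 2 gives 127 ug/mL, so compound 1 holds the lower number of the two and is the stronger inhibitor, by a gap beyond the usual scatter. The two share little in structure, so that gap says nothing about any single group.

The next compound to be measured is compound 3 `Oc1cc(Cc2ccccc2)c(O)cc1Br`, which departs from compound 1 in one place (hydrogen in place of hydroxy on an aromatic carbon). It carries hydrogen in place of hydroxy on an aromatic carbon, para to a large group, and the rest of the structure stays the same.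

Among the measured compounds shown here, no measured pair differs in one place, so nothing here tests such a change directly. The expectation starts from compound 1 at 13.9 ug/mL and is for a small move toward a higher number in this assay, one that may not clear the scatter. The estimated step of a 1.7-fold higher number from compound 1 to compound 3 (0.24 log units; within the scatter) is of that size. Compound 3 is expected at 24 ug/mL (8 ug/mL to 70 ug/mL).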

Compound 3, half-maximal inhibitory concentration: 13.3 ug/mL
For compound 3 the middle estimate is 1.8-fold (0.26 log units) above the measured one, within the range that was stated.
By their numbers in this assay, from the lowest: compounds 3 and 1 (each within the scatter of the next); then compound 2.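

In this assay, putting hydrogen in place of hydroxy on an aromatic carbon, para to a large group, gives a 1.0-fold lower number from compound 1 to compound 3 (0.02 log units; within the scatter). Among the compounds shown here, this is the first step in the set that tests a single place, and it shows that this hydroxy group can be removed without a shift that clears the scatter. Compound 3 thus holds its standing in this assay with one hydrogen-bond donor and one hydrogen-bond acceptor fewer than compound 1, so the inhibition seen with compound 1 does not depend on this hydroxy group. Nothing available explains this result.

The compounds shown compare only hydroxy and hydrogen at this position, so it remains open whether an amine, a methoxy group or a carboxylic acid there would also leave the number within the scatter or would move it beyond. For the compounds shown here, the remaining hydroxy groups and the bromine of compound 3 are also untested, as no single-place step touches them, and how much each contributes to the inhibition stays unknown.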